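The source may hold more compounds than are shown below. What is called first, only, known or untested is meant among the compounds shown, and "the series" means these compounds.

In an ADME assay on microsomes (Rattus norvegicus) for metabolic stability (on this read-out lower numbers stand for a shorter-lived compound and higher numbers for a longer-lived compound), compound 3 `O=C(C1CCN(c2ccccc2)CC1)N1N=CCC1c1ccccc1` gives 0.25 h, the lower of the two actual numbers in this small set. Compound 1 `CCC(=O)N1CCC(C(=O)N2N=CCC2c2ccccc2)CC1` gives 1.07 h, a clearly higher number. Compound 2 `O=C(c1cn[nH]c1)N1CCC(C(=O)N2N=CCC2c2ccccc2)CC1` is reported as > 2.75 h, which is a limit of the assay and not a number.

The unmeasured compound 4 `O=C(c1cocn1)N1CCC(C(=O)N2N=CCC2c2ccccc2)CC1` differs from compound 3 on an amine nitrogen in a ring: (1,3-oxazol-4-yl)carbonyl stands in place of phenyl ((1,3-oxazol-4-yl)carbonyl in place of phenyl on an amine nitrogen in a ring). Within the data shown here, two measured steps bear on this swap, and both run the opposite way, putting phenyl in place of a carbonyl-linked group. The first replaces propanoyl and gives a 4.3-fold lower number from compound 1 to compound 3 (0.63 log units; beyond the scatter). The second replaces (1H-pyrazol-4-yl)carbonyl and gives an at least 11-fold lower number from compound 2 to compound 3 (1.04 log units; beyond the scatter). Both lead downward, so removing phenyl and restoring a carbonyl-linked group is expected to raise the number in this assay by more than the scatter. The group on that carbonyl also matters, as an at least 2.5-fold higher number from compound 1 to compound 2 (0.40 log units; beyond the scatter) shows, so the size of the rise remains uncertain. The expected step is an 8.8-fold higher number from compound 3 to compound 4 (0.94 log units; beyond the scatter). For compound 4 the estimate is 2.2 h, with an expected range from 0.8 h to 5 h.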

Compound 4, half-life: 0.533 h
Compound 4: the middle estimate sits 4.1-fold (0.62 log units) above what was measured, outside the stated range (below it).
By their numbers in this assay, from the lowest: compound 3; then compounds 4 and 1 (each within the scatter of the next). At a limit, above all of these: compound 2.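

In this assay, a carbonyl-linked group on the amine nitrogen in the ring does not guarantee a large rise over phenyl: with (1,3-oxazol-4-yl)carbonyl the gain is only a 2.1-fold higher number from compound 3 to compound 4 (0.33 log units; beyond the scatter). On the carbonyl carbon, 1,3-oxazol-4-yl and ethyl cannot be told apart, since the result is a 2.0-fold lower number from compound 1 to compound 4 (0.30 log units; within the scatter), so this aromatic ring offers no clear gain over the small chain. The choice of ring on that carbon does matter, however, as 1,3-oxazol-4-yl in place of 1H-pyrazol-4-yl gives an at least 5.1-fold lower number from compound 2 to compound 4 (0.71 log units; beyond the scatter), which means that the high position of compound 2 belongs to its particular ring and not to every five-membered aromatic ring on the carbonyl.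

Going by these compounds, how long-lived compound 2 really is cannot be read, and the full size of that last step stays unknown, as its entry is a limit of the assay and not a number: the limit of > 2.75 h in this assay, at which 1 of the 4 values shown sits. On these data alone, it also remains open whether a 1,3-thiazol-4-yl ring in place of 1,3-oxazol-4-yl, or a longer chain in place of ethyl, would shift the half-life.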